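A single stereocentre left undrawn: compound 2 to compound 4

The compounds below may be only part of what the source reports. "The series", "measured", "known", "first", "only" and "open" are said of these compounds alone.

Compound 1, `Cc1c(C)c2c(c(C)c1O)CC[C@@](C)(CC(=O)O)O2`: 17000 nM
Compound 2, `Cc1c(C)c2c(c(C)c1O)CC[C@@](C)(CC(=O)[N-][N+](C)(C)C)O2`: 9000 nM
Compound 3, `Cc1c(C)c2c(c(C)c1O)CC[C@@](C)(CCN(C)C)O2`: 1000 nM

In a functional assay (brain) for inhibition, with Rattus norvegicus as the target (a lower number here means a stronger inhibitor, a higher number a weaker inhibitor), compound 2 lies close to compound 1, the step of a 1.9-fold lower number from compound 1 to compound 2 (0.28 log units; within the scatter) being within the scatter, and furthest from compound 3, with a 9.0-fold lower number from compound 2 to compound 3 (0.95 log units; beyond the scatter). The larger step in this set, a 17-fold lower number from compound 1 to compound 3 (1.23 log units; beyond the scatter), concerns an exchange of groups on the chain and not a stereocentre.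

Compound 4, `Cc1c(C)c2c(c(C)c1O)CCC(C)(CC(=O)[N-][N+](C)(C)C)O2`, has not been measured in this assay. Its difference from compound 2 is the two compounds have the same atoms and bonds; at least one stereo element is drawn with a configuration in one of them and without one in the other: 1 of 1 stereo elements differ; a stereocentre at a saturated ring carbon is drawn S in compound 2 and without a configuration in compound 4. Going by the values given here, none of the measured steps bears on such a change: all three alter the chain, while the configuration at the ring carbon stays as drawn in compound 2. Compound 4 may therefore hold the same enantiomer as compound 2 together with its mirror image, or an undefined mixture, so the expectation rests on the value of compound 2 alone.

Compound 4 is expected to show 12000 nM, within 6000 nM to 30000 nM. The step of a 1.3-fold higher number from compound 2 to compound 4 (0.12 log units; within the scatter) is thus estimated to stay within the scatter, with no clear direction.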

Compound 4, half-maximal inhibitory concentration: 6000 nM
Compound 4: middle estimate off by 2.0-fold (0.30 log units), on the high side; low and high end bracket the measured number.
By their numbers in this assay, from the lowest: compound 3; then compounds 4, 2 and 1 (each within the scatter of the next, the first and the last beyond it).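

In this assay, going by these compounds alone, the configuration at the ring carbon is touched for the first time, and the result is a 1.5-fold lower number from compound 2 to compound 4 (0.18 log units; within the scatter). Within the data shown here, all the earlier steps altered the chain, so they could say nothing about this stereocentre; now the position shows that, at this level of inhibition, a drawn S centre and an undrawn one cannot be told apart. The comparison rests on a single structural distinction: the fact that one of compounds 2 and 4 is drawn with a defined configuration and the other without, at the place where they differ

Going by these compounds, what the mirror image on its own would give stays open, since the content of compound 4 is undefined and it may or may not include that form. Also open, on these data alone, is whether the configuration would count for more with a primary amine or a longer chain carrying the dimethylamino group at this position.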